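Cyclopropyl to Methoxymethyl on the Difluorinated Ring

This account rests on a few compounds, and the source may have more. Where it says the series, first, only, none or still open, it means among the compounds named here.

Compound 1, `Cc1cc(F)c(Cc2cnc(Nc3ccc(C#N)c(Cl)c3)o2)c(F)c1`: 31000 nM
Compound 2, `CC(C)c1cc(F)c(Cc2cnc(Nc3ccc(C#N)c(Cl)c3)o2)c(F)c1`: 5000 nM
Compound 3, `N#Cc1ccc(Nc2ncc(Cc3c(F)cc(C4CC4)cc3F)o2)cc1Cl`: 65000 nM

All three were tested in an ADME assay on MT2 cells (Homo sapiens) for inhibition; a higher number here means that more compound is tolerated, a lower number that less compound is tolerated. Compound 3 stands highest of the three numbers; its nearest neighbour is compound 1 and its furthest is compound 2. Two measured steps end at compound 3: a 2.1-fold higher number from compound 1 to compound 3 (0.32 log units; beyond the scatter) and a 13-fold higher number from compound 2 to compound 3 (1.11 log units; beyond the scatter). Both steps raise the number when cyclopropyl enters, the second one strongly.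

Compound 4, `COCc1cc(F)c(Cc2cnc(Nc3ccc(C#N)c(Cl)c3)o2)c(F)c1`, differs from compound 3 by methoxymethyl in place of cyclopropyl on an aromatic carbon. Among the measured compounds shown here, no measured step involves methoxymethyl, so the only guidance is that the two steps leading to compound 3 both climb; reversing the cyclopropyl therefore points downward, though how far a methoxymethyl would carry the number is unknown. A modest fall is expected, estimated as a 2.2-fold lower number from compound 3 to compound 4 (0.34 log units; beyond the scatter) in this assay, landing nearer the value of compound 1 than that of compound 2. For compound 4 the estimate is 30000 nM, with a range from 8000 nM to 100000 nM.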

Compound 4, half-maximal cytotoxic concentration: 15000 nM
For compound 4 the middle estimate is 2.0-fold (0.30 log units) above the measured one; the measured number falls inside the stated range.
By their numbers in this assay, from the lowest: compound 2; then compound 4; then compound 1; then compound 3.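

In this assay, methoxymethyl does not reach the level of cyclopropyl, even though each group has 3 heavy atoms: the swap gives a 4.3-fold lower number from compound 3 to compound 4 (0.64 log units; beyond the scatter) and so shows that this position responds to more than the heavy-atom count. Methoxymethyl still stands clear of isopropyl, with a 3.0-fold higher number from compound 2 to compound 4 (0.48 log units; beyond the scatter) in the same assay, while placing methoxy on the methyl carbon gives a 2.1-fold lower number from compound 1 to compound 4 (0.32 log units; beyond the scatter) and thus moves the number down from the methyl compound. Nothing available explains these differences.

The swap from cyclopropyl removes the ring and adds the oxygen together, so the compounds shown cannot separate those two changes. From the compounds shown here alone, how hydroxymethyl, ethoxymethyl or an aminomethyl group would fare at this position remains open.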